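The source may report more compounds than this note shows. Statements on the series, on what has been measured and on what is new or still open speak of the compounds shown alone.

Compound 1 `COC(=O)c1c(F)cccc1OC(=O)COc1cc(O)c2c(=O)cc(-c3ccccc3)oc2c1`: 40300 nM
Compound 2 `COC(=O)c1ccc(C)cc1OC(=O)COc1cc(O)c2c(=O)cc(-c3ccccc3)oc2c1`: 31100 nM
Compound 3 `COC(=O)c1cccc(OC)c1OC(=O)COc1cc(O)c2c(=O)cc(-c3ccccc3)oc2c1`: 36800 nM

In a functional assay on cells (T-cell, Mus musculus, strain BALB/c) for inhibition, read by MTT assay, with a stated time of 72 h (a higher number here means a weaker inhibitor, a lower number a stronger inhibitor), the three measured compounds lie close together; compound 3 sits within the scatter of both compound 1 and compound 2, so none of the three can be told apart on these numbers. Compound 4 `COC(=O)c1cccc(C)c1OC(=O)COc1cc(O)c2c(=O)cc(-c3ccccc3)oc2c1` is derived from compound 3 by the change (methyl in place of methoxy on an aromatic carbon). Among the measured compounds shown here, the only measured step on this aromatic ring, a 1.3-fold lower number from compound 1 to compound 2 (0.11 log units; within the scatter), exchanged one substituted ring for another without moving the number beyond the scatter. That step bears only loosely on the present change, yet nothing seen points to a large effect, so the expected step is a 1.1-fold lower number from compound 3 to compound 4 (0.02 log units; within the scatter), none beyond the scatter. Compound 4 is therefore estimated at 35000 nM, within a range from 18000 nM to 65000 nM.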

Compound 4, half-maximal inhibitory concentration: 39100 nM
Beside the measured number, compound 4's estimate is 1.1-fold (0.05 log units) below it, and the stated range covers the measured number.
By their numbers in this assay, from the lowest: compounds 2, 3, 4 and 1 (each within the scatter of the next).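

In this assay, methyl in place of methoxy at this position gives a 1.1-fold higher number from compound 3 to compound 4 (0.03 log units; within the scatter), so this direct exchange on the aromatic carbon does not separate the two groups. Changing the ring's substituents more widely gives a 1.3-fold higher number from compound 2 to compound 4 (0.10 log units; within the scatter) and a 1.0-fold lower number from compound 1 to compound 4 (0.01 log units; within the scatter), which adds compound 4 to a set that cannot be told apart. No measurement is available that would explain this flat result. Still open, on these data alone, is whether an amine, a carboxylic acid or a longer chain at this position would move the number beyond the scatter.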